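This account rests on a few compounds, and the source may have more. Where it says the series, first, only, none or still open, it means among the compounds named here.

Measured so far:
compound 1 `Cc1nn(C)c(Oc2cccc(F)c2)c1/C=N\CCCCCOc1cc2oc(=O)cc(C)c2cc1Cl` gives 11800 nM
compound 2 `Cc1ccc(Oc2c(/C=N\CCCCCOc3cc4oc(=O)cc(C)c4cc3Cl)c(C)nn2C)cc1` gives 11100 nM
compound 3 `Cc1nn(C)c(Oc2ccc(F)cc2F)c1/C=N\CCCCCCOc1cc2oc(=O)cc(C)c2cc1Cl` gives > 25000 nM

All three compounds were tested in a functional assay on SMMC-7721 cells (Homo sapiens) for antiproliferative activity, read by MTT assay, with a stated time of 72 h; a lower number here means a stronger inhibitor, a higher number a weaker inhibitor. Compound 1 and compound 2 differ only in the aryl group sitting on the oxygen, and the step of a 1.1-fold lower number from compound 1 to compound 2 (0.03 log units; within the scatter) shows that swapping one aryl for another there made no real difference. Compound 3 carries a longer chain and a 2,4-difluorophenyl group, and for compound 3 the assay reports only a limit, > 25000 nM, rather than a number; this is the limit described in the limit of > 25000 nM in this assay, at which 1 of the 3 values shown sits.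

Compound 4 `Cc1nn(C)c(Oc2ccc(I)cc2)c1/C=N\CCCCCCOc1cc2oc(=O)cc(C)c2cc1Cl` is compound 3 with one change: 4-iodophenyl in place of 2,4-difluorophenyl on an oxygen on an aromatic ring. Going by the values given here, the only measured step that touches this position, from compound 1 to compound 2, lay within the scatter, so a similar aryl swap in compound 4 is not expected to move the number beyond the scatter either. Compound 4 is therefore expected to stay close to where compound 3 stands, with an expected step of a number no higher from compound 3 to compound 4 (the limit leaves the size open). The estimate for compound 4 in this assay is 25000 nM, in a range from 8000 nM to 60000 nM, with a fair chance that the assay again reports only a limit.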

Compound 4, half-maximal inhibitory concentration: 13300 nM
For compound 4 the middle estimate is 1.9-fold (0.27 log units) above the measured one; the measured number falls inside the stated range.
By their numbers in this assay, from the lowest: compounds 2, 1 and 4 (each within the scatter of the next). At a limit, above all of these: compound 3.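

In this assay the earlier step at this position came from compounds sharing the chain of compound 1, so it said nothing about the longer chain of compound 3. Compound 3 stands at a limit and not at a number: the limit of > 25000 nM in this assay, at which 1 of the 4 values shown sits. Compound 4 keeps that longer chain and still gives a number, so this chain does not by itself hold a compound at the limit, and with 4-iodophenyl in place of 2,4-difluorophenyl on an oxygen on an aromatic ring the result reads as an at least 1.8-fold lower number from compound 3 to compound 4 (0.27 log units; that floor lies within the scatter) with only a floor for its size, so this change may be small or large.

The compounds shown leave open how the chain acts on its own, as no two of them differ in the chain alone. They also leave open how this position would read with an aromatic ring carrying an amine or a carboxylic acid in place of the 4-iodophenyl group.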